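Swapping the aryl amide on a sulfamoylurea piperidine

The source may hold more compounds than are shown below. What is called first, only, known or untested is meant among the compounds shown, and "the series" means these compounds.

Of the compounds shown here, two with a shared core have been measured. Compound 1 `Cn1cc(C(=O)NCCC2CCN(S(=O)(=O)NC(=O)NC3CCCCC3)CC2)c(=O)n(C)c1=O` carries a dimethyl-substituted heteroaromatic ring on the carbonyl carbon; in a functional assay on the whole organism (blood) with Rattus norvegicus as the target, with stated times of 24 h and 1 h, at a dose of 15 mg/kg by the intraperitoneal route (a higher number here means a stronger effect of the compound at the dose given, a lower number a weaker effect), compound 1 gives 15%. Going by the values given here, compound 2 `COc1ncccc1C(=O)NCCC1CCN(S(=O)(=O)NC(=O)NC2CCCCC2)CC1`, with a 2-methoxypyridin-3-yl group on the same carbonyl carbon, gives 35% in this assay, the higher of the two numbers, with compound 1 the only neighbour and the step of a number 20 percentage points higher from compound 1 to compound 2 (beyond the scatter).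

Compound 3 `O=C(NC1CCCCC1)NS(=O)(=O)N1CCC(CCNC(=O)c2cccc3c2OCCO3)CC1` is the next step, and it again alters the group on the carbonyl carbon: 2,3-dihydro-1,4-benzodioxin-5-yl in place of 2-methoxypyridin-3-yl on a carbonyl carbon. Among the compounds with values here, the one step measured, from compound 1 to compound 2, touched the same place and was modest in size, but it does not tell how this assay responds to a 2,3-dihydro-1,4-benzodioxin-5-yl group, so no direction can be argued from it. The expected step is therefore a number 5 percentage points lower from compound 2 to compound 3 (within the scatter), essentially within the scatter. Compound 3 is thus estimated at 30% in this assay, with a likely range from 10% to 55%.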

Compound 3, a percentage reported as activity, at one dose (the size of the read-out at that dose, not a potency): 42%
Compound 3: middle estimate off by 12 percentage points, on the low side; measured number inside the range.
By their numbers in this assay, from the lowest: compound 1; then compounds 2 and 3 (each within the scatter of the next).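

With the 2,3-dihydro-1,4-benzodioxin-5-yl group on the carbonyl carbon, this assay gives a number 7 percentage points higher from compound 2 to compound 3 (within the scatter), so this position accepts a bicyclic group with an aromatic ring of carbon only about as well as the 2-methoxypyridin-3-yl group, whose single aromatic ring holds one hetero atom. Measured against the group of compound 1, the new group gives a number 27 percentage points higher from compound 1 to compound 3 (beyond the scatter), so two differently built groups now stand beyond the scatter above compound 1, and a hetero atom in the aromatic ring is not needed to reach that level. Nothing available here explains these differences between the groups.

The compounds shown leave open whether the oxygen atoms of the two better groups matter at all, which a plain phenyl group on the same carbonyl carbon would address, and whether a carboxylic acid on that ring would be tolerated. From the compounds shown here alone, each figure is also a read-out at one dose, so how the compounds compare in potency remains open.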